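A few compounds are considered here, and "the series" means these few. Any claim that something is new, unique, unknown or untested is made for them only; others in the source may bear on it.

Measured in a functional assay on PC-3 cells (Homo sapiens) for inhibition; a lower number here means a stronger inhibitor, a higher number a weaker inhibitor:
compound 1 `Cc1ccc(O)c(/C=N\NC(=O)c2oc3cccc(O)c3c2C)c1`: 7350 nM
compound 2 `Cc1c(C(=O)N/N=C\c2ccccc2)oc2cccc(O)c12`: 29200 nM
compound 3 `Cc1c(C(=O)N/N=C\c2cccc(Br)c2O)oc2cccc(O)c12`: 16600 nM

Compound 1 gives the lowest number of the three; compound 2 lies a 4.0-fold higher number from compound 1 to compound 2 (0.60 log units; beyond the scatter) and compound 3 lies a 2.3-fold higher number from compound 1 to compound 3 (0.35 log units; beyond the scatter), both steps beyond the scatter. Between compound 2 and compound 3 the gap is a 1.8-fold lower number from compound 2 to compound 3 (0.25 log units; within the scatter), within the scatter.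

Compound 4 `Cc1c(C(=O)N/N=C\c2ccc(Br)cc2O)oc2cccc(O)c12` is not yet measured. It differs from compound 1 as follows: 4-bromo-2-hydroxyphenyl in place of 2-hydroxy-5-methylphenyl on a carbon with a double bond to nitrogen

Within the data shown here, the step bearing on this change is the one from compound 1 to compound 3, where a bromo-hydroxyphenyl also took the place of the hydroxy-methylphenyl and gave a 2.3-fold higher number from compound 1 to compound 3 (0.35 log units; beyond the scatter). A modest rise of similar size is therefore expected in this assay for compound 4: estimated 14000 nM (range 7000 nM to 28000 nM), meaning an expected step of a 1.9-fold higher number from compound 1 to compound 4 (0.28 log units; within the scatter).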

Compound 4, half-maximal inhibitory concentration: 2050 nM
Compound 4: the middle estimate sits 6.8-fold (0.83 log units) above what was measured; the whole stated range lies above it.
By their numbers in this assay, from the lowest: compound 4; then compound 1; then compounds 3 and 2 (each within the scatter of the next).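

In this assay the change from 3-bromo-2-hydroxyphenyl to 4-bromo-2-hydroxyphenyl on this carbon gives an 8.1-fold lower number from compound 3 to compound 4 (0.91 log units; beyond the scatter) as its step, so the place of the bromine on the ring matters and a bromo-hydroxyphenyl cannot be read as one kind of change. The 4-bromo-2-hydroxyphenyl group also improves on 2-hydroxy-5-methylphenyl with a 3.6-fold lower number from compound 1 to compound 4 (0.55 log units; beyond the scatter) as its step and on phenyl with a 14-fold lower number from compound 2 to compound 4 (1.15 log units; beyond the scatter) as its step, though compound 3 shows that bromine alone does not secure this. No supporting data explain these differences.

Open, going by these compounds, is whether the hydroxyl is needed alongside the bromine, as a 4-bromophenyl group would show. Also open, on these data alone, is whether bromine itself is required at this place, as a 4-chloro-2-hydroxyphenyl or 4-methoxy-2-hydroxyphenyl group would show.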